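A New Group on the Nitrogen of Compound 2

The source may report more compounds than this note shows. Statements on the series, on what has been measured and on what is new or still open speak of the compounds shown alone.

Compound 1 `O=c1cc(/C=N\c2ccccc2O)c2c(OCc3ccccc3)cc(OCc3ccccc3)cc2o1`: 348000 nM
Compound 2 `O=c1cc(/C=N\O)c2ccc(OCc3ccccc3)cc2o1`: > 2000000 nM

In a functional assay, read by spectrophotometry, with a stated time of 1 h (on this read-out lower numbers stand for stronger inhibition and higher numbers for weaker inhibition), compound 2 has no exact number and gives only a limit, > 2000000 nM. Compound 3 `O=c1cc(/C=N\c2ccccc2O)c2ccc(OCc3ccccc3)cc2o1` keeps the core of compound 2 but changes the group on a double-bonded nitrogen: 2-hydroxyphenyl in place of hydroxy on a double-bonded nitrogen. Compound 1 also carries 2-hydroxyphenyl on a double-bonded nitrogen, on a different core, and gives 348000 nM. A sizeable move toward stronger inhibition is therefore expected. The estimated step in this assay is an at least 4.0-fold lower number from compound 2 to compound 3 (0.60 log units; beyond the scatter). For compound 3 the expected value is 500000 nM, with an estimated range of 150000 nM to 1500000 nM.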

Compound 3, half-maximal inhibitory concentration: "not active" (no number reported)
Compound 3 has no reported number here; the estimate stays without a comparison.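

No step from compound 2 to compound 3 can be read, because compound 3 is reported as "not active" without a number and compound 2 has only a limit: the limit of > 2000000 nM in this assay, at which 1 of the 3 values shown sits.

Going by these compounds, how strongly compound 3 inhibits, and whether 2-hydroxyphenyl in place of hydroxy changes inhibition on this core, stays open.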